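Replacing the difluorophenyl of compound 2 with difluorocyclobutyl

This account rests on a few compounds, and the source may have more. Where it says the series, first, only, none or still open, it means among the compounds named here.

Measured so far:
Compound 1 `FC(F)(F)c1cccc(Nc2cc3[nH]c(Nc4ccc(N5CCN(CC6CC6)CC5)cn4)nc3cn2)c1`: 130000 nM
Compound 2 `Fc1ccc(Nc2cc3[nH]c(Nc4ccc(N5CCN(CC6CC6)CC5)cn4)nc3cn2)cc1F`: 10000 nM

In a physicochemical assay for solubility, read by HPLC, using the shake flask method, in phosphate buffer, measured as kinetic solubility, with a stated time of 20 h, at pH 6.5 (on this read-out lower numbers stand for lower solubility and higher numbers for higher solubility), compound 2 gives the lower of the two numbers, 10000 nM. Compound 3 `FC1(F)CC(Nc2cc3[nH]c(Nc4ccc(N5CCN(CC6CC6)CC5)cn4)nc3cn2)C1`, not yet measured, has 3,3-difluorocyclobutyl in place of 3,4-difluorophenyl on a nitrogen on an aromatic ring. Among the measured compounds shown here, only one measured step bears on this place, a 13-fold lower number from compound 1 to compound 2 (1.11 log units; beyond the scatter), which is large and beyond the scatter. For the measured compounds named here, that step exchanged one phenyl group for another, and no measured step leaves the aromatic ring, so it guides the expectation only loosely. A moderate rise is expected, a 4.0-fold higher number from compound 2 to compound 3 (0.60 log units; beyond the scatter). For compound 3 the estimate is 40000 nM, with an expected range of 10000 nM to 150000 nM.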

Compound 3, solubility: 190000 nM
Compound 3: the middle estimate sits 4.8-fold (0.68 log units) below what was measured, and the stated range ends below it.
By their numbers in this assay, from the lowest: compound 2; then compounds 1 and 3 (each within the scatter of the next).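

In this assay, the place on the nitrogen on an aromatic ring does not need a phenyl group to give a high number: 3,3-difluorocyclobutyl in place of 3,4-difluorophenyl gives a 19-fold higher number from compound 2 to compound 3 (1.28 log units; beyond the scatter). In place of 3-(trifluoromethyl)phenyl, the same group gives a 1.5-fold higher number from compound 1 to compound 3 (0.16 log units; within the scatter), so these two groups cannot be told apart here. Nothing available explains either step. Going by these compounds, what plain cyclobutyl, or a ring carrying an amine such as piperidinyl, would give at this place remains open.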